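Adding a 4-chlorophenyl group to compound 1

The source may hold more compounds than are shown below. What is called first, only, known or untested is meant among the compounds shown, and "the series" means these compounds.

In an ADME assay on KB cells (Homo sapiens) for cytotoxicity (on this read-out lower numbers stand for an effect already at smaller amounts and higher numbers for an effect only at larger amounts of compound), compound 1 `COc1cc2c(c(OC)c1OC)C(=O)[C@]1(OC)C=C[C@H]2N(C(=O)OCC(C)C)N1C(=O)OCC(C)C` reads (> 300 ug/mL), which is a limit of the assay and not a number. Compound 4 `COc1cc2c(c(OCc3ccc(Cl)cc3)c1OC)C(=O)[C@]1(OC)C=C[C@H]2N(C(=O)OCC(C)C)N1C(=O)OCC(C)C` has the same core and changes in one place 4-chlorophenyl in place of hydrogen on a saturated chain carbon bound to an oxygen on an aromatic ring with 4-chlorophenyl in place of hydrogen on a saturated chain carbon bound to an oxygen on an aromatic ring. Among the compounds with values here, no measured pair shows this exact change directly. The nearest evidence comes from compound 2 `CCOC(=O)N1[C@@H]2C=C[C@@](OC)(C(=O)c3c2cc(OC)c(OC)c3OCc2ccccc2F)N1C(=O)OCC` (99.7 ug/mL) and compound 3 `CCOC(=O)N1[C@@H]2C=C[C@@](OC)(C(=O)c3c2cc(OC)c(OC)c3OCc2ccc(OC)cc2)N1C(=O)OCC` (63.1 ug/mL), which also carry a substituted phenyl on that carbon, although their other chains differ from those of compound 4. Within the data shown here, the one measured step between them (a 1.6-fold lower number from compound 2 to compound 3 (0.20 log units; within the scatter)) swaps one substituted phenyl for another, and so it suggests only that the choice of group need not matter much. On the values of compound 2 and compound 3, a clear step toward a lower number is expected (an at least 5.0-fold lower number from compound 1 to compound 4 (0.69 log units; beyond the scatter)) for this change. Compound 4 is estimated at 60 ug/mL with an expected range from 20 ug/mL to 180 ug/mL in this assay for now.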

Compound 4, concentration for half-maximal effect: 42 ug/mL
Compound 4: the middle estimate sits 1.4-fold (0.15 log units) above what was measured; the range from low to high includes it.
By their numbers in this assay, from the lowest: compounds 4, 3 and 2 (each within the scatter of the next, the first and the last beyond it). At a limit, above all of these: compound 1.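

In this assay, 4-chlorophenyl in place of hydrogen on a saturated chain carbon bound to an oxygen on an aromatic ring gives an at least 7.1-fold lower number from compound 1 to compound 4 (0.85 log units; beyond the scatter). The earlier step only swapped one substituted phenyl for another and stayed within the scatter, whereas this one starts from the hydrogen and shows that adding a substituted phenyl at this place can move the number beyond the scatter. The full size of the step stays unknown, since compound 1 stands at a limit of the assay and not at a number: the limit of > 300 ug/mL in this assay, at which 1 of the 4 values shown sits.

As far as these compounds go, it remains open whether the aromatic ring is needed, or whether a longer chain or an amine in place of 4-chlorophenyl would do the same. From the compounds shown here alone, it is also open how 2-fluorophenyl and 4-methoxyphenyl would compare with 4-chlorophenyl on the exact core of compound 4.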